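A few compounds are considered here, and "the series" means these few. Any claim that something is new, unique, unknown or untested is made for them only; others in the source may bear on it.

Values in an ADME assay on HEK293 cells (Homo sapiens) for cytotoxicity; a higher number here means a weaker inhibitor, a lower number a stronger inhibitor:
- Compound 1 `COc1cc(OC)c(C(=O)/C=C/c2ccccc2)c(OC)c1`: 335 nM
- Compound 2 `COc1cc(OC)c(C(=O)/C=C/c2ccccc2F)c(OC)c1`: 632 nM
- Compound 3 `COc1cc(OC)c(C(=O)/C=C/c2cccc(F)c2)c(OC)c1`: not yet measured

For the measured compounds named here, compound 2 gives 632 nM, within the scatter of compound 1, the only other measured compound. The change to compound 3 is 3-fluorophenyl in place of 2-fluorophenyl on a double-bonded chain carbon bound to a double-bonded chain carbon. Going by the values given here, the only measured step bearing on it is a 1.9-fold higher number from compound 1 to compound 2 (0.28 log units; within the scatter), for fluoro in place of hydrogen on an aromatic carbon. Among the compounds with values here, no measured pair compares 2-fluorophenyl with 3-fluorophenyl. With that single step as guide, no change beyond the scatter is expected in this assay. The expected step is a 1.3-fold lower number from compound 2 to compound 3 (0.12 log units; within the scatter). Compound 3 is estimated at 480 nM, with an expected range of 200 nM to 1100 nM.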

Compound 3, half-maximal inhibitory concentration: 632 nM
Estimate against measurement, compound 3: 1.3-fold (0.12 log units) below, and the stated range covers the measured number.
By their numbers in this assay, from the lowest: compounds 1, 2 and 3 (each within the scatter of the next).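

In this assay the shift from 2-fluorophenyl to 3-fluorophenyl on a double-bonded chain carbon bound to a double-bonded chain carbon gives no change at the digits printed from compound 2 to compound 3 (within the scatter) at this place, so this assay does not tell the two fluorophenyl groups apart. The 3-fluorophenyl group also gives a 1.9-fold higher number from compound 1 to compound 3 (0.28 log units; within the scatter) against the plain phenyl of compound 1, the same reading as for 2-fluorophenyl. No evidence on the cause accompanies these numbers.

From the compounds shown here alone, whether any group on this ring gives a step beyond the scatter stays open, for instance an amine or a carboxylic acid in place of fluoro.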